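Nitro for Cyano on Two Cores in LNCaP Cells

The compounds below may be only part of what the source reports. "The series", "measured", "known", "first", "only" and "open" are said of these compounds alone.

Compound 1 `CC(O)(COc1cc(C(F)(F)F)cc(C(F)(F)F)c1)C(=O)Nc1ccc(C#N)cc1C(F)(F)F` and compound 2 `CC(O)(COc1cc(C(F)(F)F)cc(C(F)(F)F)c1)C(=O)Nc1ccc([N+](=O)[O-])cc1C(F)(F)F` share one open-chain core. In a functional assay on LNCaP cells (Homo sapiens) for antiproliferative activity, read by fluorescence and propidium iodide staining, with a stated time of 96 h (on this read-out lower numbers stand for stronger inhibition and higher numbers for weaker inhibition), compound 1 gives 3560 nM, and compound 2 gives 24000 nM. The change between them, (nitro in place of cyano on an aromatic carbon), makes the step of a 6.7-fold higher number from compound 1 to compound 2 (0.83 log units; beyond the scatter). Compound 3 `CC1(C)C(=O)N(c2ccc(C#N)cc2C(F)(F)F)C(=S)N1c1cc(C(F)(F)F)cc(C(F)(F)F)c1` rests on a second core; the difference between the two cores is not broken down here. In this assay compound 3 gives "nd(insoluble)" (no result reported), that is, no single number, as it was insoluble. Compound 4 `CC1(C)C(=O)N(c2ccc([N+](=O)[O-])cc2C(F)(F)F)C(=S)N1c1cc(C(F)(F)F)cc(C(F)(F)F)c1` carries the same change on this second core, (nitro in place of cyano on an aromatic carbon). Without a number for compound 3 there is no anchor, so the expectation for compound 4 rests only on the step of a 6.7-fold higher number from compound 1 to compound 2 (0.83 log units; beyond the scatter) and on the weak, modest read-out of compound 2. Compound 4 is expected to give about 20000 nM in this assay, between 4000 nM and 100000 nM, with a real chance that again no number results.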

Compound 4, half-maximal inhibitory concentration: 4670 nM
The estimate for compound 4 lay 4.3-fold (0.63 log units) above the measured number, within the range that was stated.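

Compound 3 gave no number, so no new step can be read between compound 3 and compound 4. Whether nitro in place of cyano acts alike on both cores stays open, and nothing shown bears on why.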